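The source may report more compounds than this note shows. Statements on the series, on what has been measured and on what is new or still open speak of the compounds shown alone.

Measured compounds and their values:
- Compound 1, `Cc1nc(NCCCNS(C)(=O)=O)nc2ccc(NC(=O)/C=C/c3ccc(OC(F)(F)F)cc3)cc12`: 54 nM
- Compound 2, `COCCC1(O)CCN(c2nc(C)c3cc(NC(=O)/C=C/c4ccc(Cl)cc4)ccc3n2)CC1`: 245 nM
- Compound 3, `Cc1nc(N2CCC(N3CCCC3=O)CC2)nc2ccc(NC(=O)/C=C/c3ccc(OC(F)(F)F)cc3)cc12`: 11 nM

All three were tested in an assay on CHO-K1 cells for displacement of a labelled ligand from melanin-concentrating hormone receptor 1 (Homo sapiens), read by scintillation proximity assay, with a stated time of 2 h; a lower number here means a stronger inhibitor, a higher number a weaker inhibitor. Compound 2 stands at the high end of the three numbers: compound 1 sits a step below it, and compound 3 is furthest away with the lowest number of the set. Compound 4, `Cc1nc(N(C)C2CCCC2)nc2ccc(NC(=O)/C=C/c3ccc(Cl)cc3)cc12`, has not yet been measured. It differs from compound 2 at one place on the shared core, between two ring nitrogen atoms: cyclopentyl(methyl)amino in place of 4-hydroxy-4-(2-methoxyethyl)piperidin-1-yl on an aromatic carbon.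

Among the measured compounds shown here, the only measured step at this same position is a 4.9-fold lower number from compound 1 to compound 3 (0.69 log units; beyond the scatter), which shows that swapping the group there can move the number by a modest amount. For the measured compounds named here, compounds 2 and 3 differ in two places at once, so their values show only that the two changes together span a wider gap. No measured pair matches the present swap exactly, so the direction is uncertain; a modest move is plausible in either direction, with no strong reason to expect a large one.

On that basis compound 4 is expected to show 150 nM in this assay, within a range of 40 nM to 600 nM. The step this estimate implies is a 1.6-fold lower number from compound 2 to compound 4 (0.21 log units; within the scatter).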

Compound 4, half-maximal inhibitory concentration: 399 nM
Estimate against measurement, compound 4: 2.7-fold (0.42 log units) below; the range from low to high includes it.
By their numbers in this assay, from the lowest: compound 3; then compound 1; then compounds 2 and 4 (each within the scatter of the next).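

In this assay, cyclopentyl(methyl)amino in place of 4-hydroxy-4-(2-methoxyethyl)piperidin-1-yl on the aromatic carbon between two ring nitrogen atoms gives a 1.6-fold higher number from compound 2 to compound 4 (0.21 log units; within the scatter). The earlier step at this position, a 4.9-fold lower number from compound 1 to compound 3 (0.69 log units; beyond the scatter), showed that a swap there can move the number, whereas this one shows that a swap can leave it within the scatter, even as the group goes from 11 heavy atoms to 7 and loses its one hydrogen-bond donor. No measurement given here offers a reason for this result.

The compounds shown leave open whether the same swap would also stay within the scatter on a compound carrying trifluoromethoxy rather than chloro on the far phenyl ring. They also leave open how a group such as a carboxylic acid or a primary amine would read at this position.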